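Ring Contraction of a Hydroxy Amide: Stability Outlook

The compounds below may be only part of what the source reports. "The series", "measured", "known", "first", "only" and "open" are said of these compounds alone.

Measured compounds:
compound 1, `N#Cc1ccc(-c2cnc(N)c(-c3ccc(N)nc3)n2)cc1`: > 90%
compound 2, `Nc1ncc(-c2ccc(C(=O)N3CCC(O)CC3)cc2)nc1-c1ccc(C(F)(F)F)cc1`: > 90%

In an ADME assay on microsomes from liver (Rattus norvegicus) for metabolic stability, read by LC-MS, using NADPH, with a stated time of 30 min, tested at 0.1 uM, in the presence of a further agent that is not named here (on this read-out lower numbers stand for a less stable compound and higher numbers for a more stable compound), compound 1 gives > 90%, which is a limit of the assay rather than a number. Compound 2 likewise gives > 90% in this assay, also a limit. Compound 2 therefore stands at the limit of > 90% in this assay, at which 2 of the 2 values shown sit, alongside compound 1. Among the compounds with values here, no step between two measured compounds is available.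

Compound 3, `Nc1ncc(-c2ccc(C(=O)N3CC[C@@H](O)C3)cc2)nc1-c1ccc(C(F)(F)F)cc1`, differs from compound 2 in one place: 3-hydroxypyrrolidin-1-yl in place of 4-hydroxypiperidin-1-yl on a carbonyl carbon. The step from compound 2 to compound 3 is expected to stay within the usual scatter, estimated as a number at least 2 percentage points lower from compound 2 to compound 3 (that floor lies within the scatter). Compound 3 is thus expected to give about 88%, within 70% to 97%.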

Compound 3, percent of the compound remaining: > 90%
Compound 3: no number, only a limit; the forecaster's own chance of this, stated with the estimate: 55%; at least 2 percentage points between middle value and limit.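

Within the data shown here, compound 2 and compound 3 each give only a limit of the assay in this assay, so no step between them can be read: the limit of > 90% in this assay, at which 3 of the 3 values shown sit.

The compounds shown leave open whether 3-hydroxypyrrolidin-1-yl in place of 4-hydroxypiperidin-1-yl changes the stability at all.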